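This account rests on a few compounds, and the source may have more. Where it says the series, first, only, none or still open, it means among the compounds named here.

Compound 1 `Cc1ccc(NCc2cn(-c3ccccc3)nc2-c2ccc(Br)cc2)cc1` gives 5980 nM
Compound 2 `Cc1ccc(-c2nn(-c3ccccc3)cc2CNc2ccc(Cl)cc2)cc1` gives 6010 nM

Both values come from a functional assay on B16-F10 cells (Mus musculus) for antiproliferative activity, read by MTT assay, with a stated time of 48 h (on this read-out lower numbers stand for stronger inhibition and higher numbers for weaker inhibition), and compound 2 stands level with compound 1 within the scatter. Compound 3 `Clc1ccc(NCc2cn(-c3ccccc3)nc2-c2ccc(Br)cc2)cc1` departs from compound 2 by one change bromo in place of methyl on an aromatic carbon (bromo in place of methyl on an aromatic carbon, para to a large group). For the measured compounds named here, no measured pair isolates this change, so the only guide is how close compound 1 at 5980 nM lies to compound 2 at 6010 nM in these data. No step beyond the scatter is expected in this assay in either direction. The expected change is a 1.2-fold lower number from compound 2 to compound 3 (0.08 log units; within the scatter) and it stays within the scatter. The estimated value for compound 3 is 5000 nM with 2200 nM to 11000 nM as the expected range.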

Compound 3, half-maximal inhibitory concentration: 4290 nM
The estimate for compound 3 lay 1.2-fold (0.07 log units) above the measured number, and the stated range covers the measured number.
By their numbers in this assay, from the lowest: compounds 3, 1 and 2 (each within the scatter of the next).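

In this assay, for the compounds shown here, the swap of 4-methylphenyl to 4-bromophenyl gives a 1.4-fold lower number from compound 2 to compound 3 (0.15 log units; within the scatter) and stands as the first measured single change at this position. Chloro in place of methyl at the other varied position gives a 1.4-fold lower number from compound 1 to compound 3 (0.14 log units; within the scatter) in the same assay, so neither single swap moves the number beyond the scatter. No measurement at hand offers a reason for this flat response. Open, from the compounds shown here alone, is how either position responds to groups further from methyl, chloro and bromo, such as an amine, a carboxylic acid or a longer chain.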